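The source may hold more compounds than are shown below. What is called first, only, known or untested is meant among the compounds shown, and "the series" means these compounds.

Compound 1 `COC(=O)c1cc(=O)c2cc(NC(=O)Nc3ccc(Cl)c(Cl)c3)ccc2[nH]1` in a functional assay on SEM cells (Homo sapiens) for antiproliferative activity, with a stated time of 72 h (a higher number here means that more compound is needed for the effect, a lower number that less compound is needed), gives only a limit, > 6350 nM. Compound 2 `COC(=O)c1cc(=O)c2cc(NC(=O)Nc3cccc(C(C)=O)c3)ccc2[nH]1` in this assay likewise gives only a limit, > 8080 nM. The step that the two limits leave unreadable from compound 1 to compound 2 is therefore not readable; both values sit at limits the limit of > 6350 nM in this assay, at which 1 of the 2 values shown sits, and (the limit of > 8080 nM in this assay, at which 1 of the 2 values shown sits). Compound 3 `COC(=O)c1cc(=O)c2cc(NC(=O)NCc3ccccc3)ccc2[nH]1` differs from compound 2 by benzyl in place of 3-acetylphenyl on an amide-type nitrogen. Among the measured compounds shown here, no measured step bears on this change, and the two limits give no direction. For compound 3 a value near the limit region is expected, with the step of a number no higher from compound 2 to compound 3 (the limit leaves the size open) taken as none beyond the scatter. Compound 3 is estimated at 8000 nM, within 2000 nM to 30000 nM.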

Compound 3, half-maximal effective concentration: > 19500 nM
Compound 3 gave a limit, no number; the forecaster's own chance of this, stated with the estimate: 75%; middle value at least 2.4-fold (0.38 log units) from the limit.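

In this assay, among the compounds shown here, compound 3 gives only a limit, > 19500 nM, and compound 1 and compound 2 also stand at limits, so no step among them can be read. The compounds shown leave open whether any group on the amide-type nitrogen changes the read-out.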